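Swapping 3-chlorophenyl for 2-chlorophenyl in compound 4

The source may hold more compounds than are shown below. What is called first, only, known or untested is meant among the compounds shown, and "the series" means these compounds.

In an ADME assay on V79 cells (Cricetulus griseus) for cytotoxicity, read by MTT assay, with a stated time of 72 h (a lower number here means a stronger inhibitor, a higher number a weaker inhibitor), compound 3 `COc1ccc(-n2nnnc2Nc2cccc(Cl)c2)cc1` gives 243000 nM and cannot be separated from its two measured relatives. Compound 1 `COc1ccc(-n2nnnc2Nc2ccccc2Br)cc1` gives 239000 nM and compound 2 `COc1ccc(-n2nnnc2Nc2ccc(Cl)cc2)cc1` gives 245000 nM so all three sit level within the scatter.

Compound 4 `COc1ccc(-n2nnnc2Nc2ccccc2Cl)cc1` is still unmeasured. It has 2-chlorophenyl in place of 3-chlorophenyl on a nitrogen on an aromatic ring and so holds the same atoms as compound 3, joined differently.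

Three measured steps change the same group. Replacing 4-chlorophenyl with 3-chlorophenyl gives a 1.0-fold lower number from compound 2 to compound 3 (0.00 log units; within the scatter) and stays within the scatter. Replacing 2-bromophenyl with 4-chlorophenyl gives a 1.0-fold higher number from compound 1 to compound 2 (0.01 log units; within the scatter) and replacing it with 3-chlorophenyl gives a 1.0-fold higher number from compound 1 to compound 3 (0.01 log units; within the scatter) and neither goes beyond the scatter.

None of these swaps has moved the number, so no step beyond the scatter is expected in this assay here. The expected change is a 1.0-fold lower number from compound 3 to compound 4 (0.01 log units; within the scatter) at this position. For compound 4 the estimate is 240000 nM with an expected range from 175000 nM to 330000 nM in this measurement.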

Compound 4, half-maximal inhibitory concentration: 246000 nM
Estimate against measurement, compound 4: 1.0-fold (0.01 log units) below; measured number inside the range.
By their numbers in this assay, from the lowest: compounds 1, 3, 2 and 4 (each within the scatter of the next).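

In this assay the chlorine has now been tried in all three ring positions: 2-chlorophenyl in place of 3-chlorophenyl gives a 1.0-fold higher number from compound 3 to compound 4 (0.01 log units; within the scatter) and 2-chlorophenyl in place of 4-chlorophenyl gives a 1.0-fold higher number from compound 2 to compound 4 (0.00 log units; within the scatter), so where the chlorine sits on this phenyl group makes no visible difference here. The halogen can also now be compared with its position held, and chloro in place of bromo on an aromatic carbon gives a 1.0-fold higher number from compound 1 to compound 4 (0.01 log units; within the scatter), so that swap leaves the number level as well. No measurement available here bears on why these numbers stay level.

Within the data shown here, every group at this place so far is a phenyl carrying a single halogen, so what an amine or a carboxylic acid on that ring would do remains open. From the compounds shown here alone, the methoxy group is also the same in all four compounds, so its part in the number remains open too.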